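Adding (4-methylphenyl)sulfonyl to compound 3

The source may hold more compounds than are shown below. What is called first, only, known or untested is meant among the compounds shown, and "the series" means these compounds.

Measured so far in an ADME assay on L02 cells (Homo sapiens) for cytotoxicity, read by MTT assay, with a stated time of 24 h; on this read-out higher numbers stand for weaker inhibition and lower numbers for stronger inhibition:
- compound 1 `Cc1ccc(S(=O)(=O)N2C/C(=C\c3ccncc3)C(=O)/C(=C/c3ccccc3F)C2)cc1`: > 20000 nM (a limit of the assay, not a number)
- compound 2 `Cc1ccc(S(=O)(=O)N2C/C(=C\c3cccnc3)C(=O)/C(=C/c3ccccc3C(F)(F)F)C2)cc1`: 12300 nM
- compound 3 `O=C1/C(=C/c2ccncc2)CNC/C1=C\c1ccccc1C(F)(F)F`: 13400 nM

In this assay compound 3 gives 13400 nM and compound 2 gives 12300 nM, two values within the scatter of each other. The only other result is a limit, which compound 1 reaches at > 20000 nM.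

Compound 4 `Cc1ccc(S(=O)(=O)N2C/C(=C\c3ccncc3)C(=O)/C(=C/c3ccccc3C(F)(F)F)C2)cc1` is compound 3 with (4-methylphenyl)sulfonyl in place of hydrogen on an amine nitrogen in a ring. Going by the values given here, no measured pair shows this change alone, so the expectation rests on a single neighbour. Compound 2 also carries (4-methylphenyl)sulfonyl and gives 12300 nM, which offers no sign of a large shift. The expected step is a 1.0-fold lower number from compound 3 to compound 4 (0.01 log units; within the scatter), and no change beyond the scatter is expected in either direction. For compound 4 the estimated value in this assay is 13000 nM, with an expected range of 6500 nM to 26000 nM.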

Compound 4, half-maximal inhibitory concentration: 12800 nM
Compound 4: middle estimate off by 1.0-fold (0.01 log units), on the high side; the range from low to high includes it.
By their numbers in this assay, from the lowest: compounds 2, 4 and 3 (each within the scatter of the next). At a limit, above all of these: compound 1.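

In this assay, (4-methylphenyl)sulfonyl in place of hydrogen on an amine nitrogen in a ring now has a direct pair, which gives a 1.0-fold lower number from compound 3 to compound 4 (0.02 log units; within the scatter), so this large addition leaves the number within the scatter. Pyridin-4-yl in place of pyridin-3-yl on a double-bonded chain carbon gives a 1.0-fold higher number from compound 2 to compound 4 (0.02 log units; within the scatter), so the sulfonylated pair also stays within the scatter. Trifluoromethyl in place of fluoro on an aromatic carbon gives an at least 1.5-fold lower number from compound 1 to compound 4 (0.19 log units; that floor lies within the scatter), and the true size of that step stays unknown, as compound 1 reads only as a limit of the assay: the limit of > 20000 nM in this assay, at which 1 of the 4 values shown sits.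

Open, on these data alone, is whether an acetyl or methyl group on the same ring nitrogen would also stay within the scatter in this assay. Also open, as far as these compounds go, is how far the number moves with a chlorine or methoxy group in place of trifluoromethyl.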